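A few compounds are considered here, and "the series" means these few. Any claim that something is new, unique, unknown or untested is made for them only; others in the source may bear on it.

Working notes on the series. In a functional assay on MRC5 cells (Homo sapiens) for cytotoxicity, read by MTT assay, with a stated time of 48 h (a higher number here means a weaker inhibitor, a lower number a stronger inhibitor), compound 1 (`CCOC(=O)C[n+]1cccc2cc(O)ccc21`) gives 162000 nM and compound 2 (`O=C(O[C@H]1C[C@H](n2cc(F)c(=O)[nH]c2=O)O[C@@H]1COP(=O)(O)Oc1ccc2ncccc2c1)c1ccccc1`) gives 1300 nM while compound 3 (`C[n+]1cccc(OP(=O)([O-])OC[C@H]2O[C@@H](n3cc(F)c(=O)[nH]c3=O)C[C@@H]2OC(=O)c2ccccc2)c1`) gives 5750 nM as the second highest of the three numbers. Compound 3 therefore sits above compound 2 and below compound 1, with both gaps beyond the scatter. Compound 4 (`CCOC(=O)C[n+]1cccc(OP(=O)([O-])OC[C@H]2O[C@@H](n3cc(F)c(=O)[nH]c3=O)C[C@@H]2OC(=O)c2ccccc2)c1`) differs from compound 3 at one place: ethoxycarbonyl in place of hydrogen on a saturated chain carbon bound to an aromatic nitrogen with ethoxycarbonyl in place of hydrogen on a saturated chain carbon bound to an aromatic nitrogen. Going by the values given here, no measured pair isolates this change in this assay and the size of its step cannot be read from the data. Compound 1 carries the same ethoxycarbonyl chain and gives 162000 nM but shares little else with compound 3, so that number is a weak guide. No change beyond the scatter is expected, and the estimated move is a 1.1-fold higher number from compound 3 to compound 4 (0.05 log units; within the scatter) in either direction. For compound 4 the estimate is 6500 nM with an expected range from 2000 nM to 21000 nM in this read-out.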

Compound 4, half-maximal inhibitory concentration: 8600 nM
For compound 4 the middle estimate is 1.3-fold (0.12 log units) below the measured one, and the stated range covers the measured number.
By their numbers in this assay, from the lowest: compound 2; then compounds 3 and 4 (each within the scatter of the next); then compound 1.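

In this assay, going by these compounds alone, ethoxycarbonyl in place of hydrogen on a saturated chain carbon bound to an aromatic nitrogen gives a 1.5-fold higher number from compound 3 to compound 4 (0.17 log units; within the scatter), and this pair is the first to isolate the change. The position therefore tolerates the swap of methyl to (ethoxycarbonyl)methyl on this core, with no shift beyond the scatter, so the added chain does not by itself set the cytotoxicity read-out in this pair. No measurement at hand bears on why the step is this small. Still open, going by these compounds, is whether a carboxylic acid in place of the ethyl ester, or an amine or a longer chain on the same carbon, would also stay within the scatter of compound 3. A single pair also leaves open whether the same step would hold on a different core.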